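Replacing Morpholin-4-yl with Pyrrolidin-1-yl in Compound 2

This account rests on a few compounds, and the source may have more. Where it says the series, first, only, none or still open, it means among the compounds named here.

Compound 1 `N/C(=N\NC(=S)N1CCOCC1)c1ccccn1` is the plainest of three measured compounds. In a functional assay on A-431 cells (Homo sapiens) for cytotoxicity, read by MTT assay, with a stated time of 72 h (a higher number here means a weaker inhibitor, a lower number a stronger inhibitor), compound 1 gives 4800 nM. Compound 2 `Cc1cccc(/C(N)=N/NC(=S)N2CCOCC2)n1` carries one extra methyl group, and in this assay compound 2 gives 4300 nM. Among the measured compounds shown here, the only one-place step among the measured compounds is a 1.1-fold lower number from compound 1 to compound 2 (0.05 log units; within the scatter). Compound 3 `N/C(=N\NC(=S)N1CCSCC1)c1ccc(F)cn1` differs from compound 2 in more than one place, so its number can only be set side by side with the others: in this assay compound 3 gives 1200 nM, the lowest of the three. Compound 2 therefore stands second highest of the three numbers, indistinguishable from compound 1 and a clear distance above compound 3.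

Compound 4 `Cc1cccc(/C(N)=N/NC(=S)N2CCCC2)n1` has not yet been measured. It differs from compound 2 by pyrrolidin-1-yl in place of morpholin-4-yl on a thiocarbonyl carbon. For the measured compounds named here, no measured step changes this ring on its own: the single step, a 1.1-fold lower number from compound 1 to compound 2 (0.05 log units; within the scatter), concerns the methyl group and leaves the group on the thiocarbonyl carbon untouched, while compound 3 alters that group together with the rest of the molecule. There is thus no basis for expecting a step beyond the scatter in either direction in this assay. The step from compound 2 to compound 4 is expected to be a 1.2-fold lower number from compound 2 to compound 4 (0.09 log units; within the scatter). Compound 4 is estimated at 3500 nM in this assay, with a range from 1200 nM to 10000 nM.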

Compound 4, half-maximal inhibitory concentration: 4000 nM
Beside the measured number, compound 4's estimate is 1.1-fold (0.06 log units) below it; measured number inside the range.
By their numbers in this assay, from the lowest: compound 3; then compounds 4, 2 and 1 (each within the scatter of the next).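

In this assay, among the compounds shown here, this is the first time the group on the thiocarbonyl carbon is changed on its own, and pyrrolidin-1-yl in place of morpholin-4-yl gives a 1.1-fold lower number from compound 2 to compound 4 (0.03 log units; within the scatter). For the compounds shown here, with the rest of compound 2 held fixed, a six-membered non-aromatic ring with 2 hetero atoms can thus give way to a five-membered non-aromatic ring with 1 hetero atom, losing the ring oxygen and its hydrogen-bond acceptor, with no step that can be told apart from the scatter. No supporting data are available to explain this result.

From the compounds shown here alone, a single swap between two rings cannot show whether the group at this place matters in general, and the same swap on the core of compound 1 remains open. A piperazin-1-yl ring, with a second ring nitrogen, or an open-chain dimethylamino group on the thiocarbonyl carbon could still give a step beyond the scatter, so the tolerance seen here holds only for this one pair of rings.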